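Amide-nitrogen substituent change in a benzoxazinone sulfonamide series

A few compounds are considered here, and "the series" means these few. Any claim that something is new, unique, unknown or untested is made for them only; others in the source may bear on it.

Measured compounds:
Compound 1 `O=C1COc2ccc(-c3cnc(Cl)c(NS(=O)(=O)c4ccc(F)cc4)c3)cc2N1c1ccc(Cl)cc1` — 30600 nM
Compound 2 `COc1ncc(-c2ccc3c(c2)N(c2ccc(Cl)cc2)C(=O)CO3)cc1NS(=O)(=O)c1ccc(F)cc1` — 24100 nM

In a functional assay on A-375 cells (Homo sapiens) for antiproliferative activity, read by MTT assay, with a stated time of 72 h (a lower number here means a stronger inhibitor, a higher number a weaker inhibitor), compound 1 gives 30600 nM, the highest of the two numbers; the nearest is compound 2 at 24100 nM. Among the compounds with values here, the one measured step, a 1.3-fold lower number from compound 1 to compound 2 (0.10 log units; within the scatter), changes only the aromatic substituent and lies within the scatter. Compound 3 `O=C1COc2ccc(-c3cnc(Cl)c(NS(=O)(=O)c4ccc(F)cc4)c3)cc2N1C1CC1` differs from compound 1 by cyclopropyl in place of 4-chlorophenyl on an amide-type nitrogen in a ring. Within the data shown here, no measured step touches the amide-type nitrogen, so there is no direct precedent for this change. Without such a precedent, compound 3 is expected to stay close to compound 1, with a wide range: 30000 nM (8000 nM to 110000 nM), an estimated step of a 1.0-fold lower number from compound 1 to compound 3 (0.01 log units; within the scatter).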

Compound 3, half-maximal inhibitory concentration: 21800 nM
Beside the measured number, compound 3's estimate is 1.4-fold (0.14 log units) above it, and the stated range covers the measured number.
By their numbers in this assay, from the lowest: compounds 3, 2 and 1 (each within the scatter of the next).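

In this assay, within the data shown here, the first step at the amide-type nitrogen is a 1.4-fold lower number from compound 1 to compound 3 (0.15 log units; within the scatter) with cyclopropyl in place of 4-chlorophenyl. Exchanging 7 heavy atoms and a six-membered aromatic ring for 3 heavy atoms and a three-membered non-aromatic ring thus leaves the number within the scatter at this position. No available evidence explains this reading.

From the compounds shown here alone, whether an aminoethyl chain or a carboxylic acid on this nitrogen would move the number remains open. So does whether cyclopropyl gives a similar reading with methoxy in place of chloro.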